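Cyano to aminomethyl exchange carried over to a second core

A few compounds are considered here, and "the series" means these few. Any claim that something is new, unique, unknown or untested is made for them only; others in the source may bear on it.

All numbers come from a functional assay on the whole organism (strain CD1) for inhibition, with Mus musculus as the target, with stated times of 15 min and 20 min, at a dose of 10 mg/kg by the subcutaneous route; a higher number here means more inhibition at the dose given (going by the name of the read-out), a lower number less inhibition.

compound 1 `N#C/C(=C\c1ccsc1)C(=O)O` — 1.8%
compound 2 `NC/C(=C\c1ccsc1)C(=O)O` — -13.5%
compound 3 `N#C/C(=C\c1ccoc1)C(=O)O` — 30.7%

Compound 3 gives the highest number of the three, beyond the scatter against both compound 1 and compound 2. The difference between the core of compound 1 and the core of compound 3 is not broken down here.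

Within the core of compound 1, the change aminomethyl in place of cyano on a double-bonded chain carbon bound to a carbonyl carbon and a double-bonded chain carbon produced a number 15.3 percentage points lower from compound 1 to compound 2 (beyond the scatter).

Compound 4 `NC/C(=C\c1ccoc1)C(=O)O` is not yet measured. It carries the same change on the core of compound 3: aminomethyl in place of cyano on a double-bonded chain carbon bound to a carbonyl carbon and a double-bonded chain carbon.

Among the measured compounds shown here, because a number 15.3 percentage points lower from compound 1 to compound 2 (beyond the scatter) is the only instance of this change with a measurement, the expected step from compound 3 to compound 4 in this assay is taken to be of similar size, a number 15.7 percentage points lower from compound 3 to compound 4 (beyond the scatter), with wide uncertainty since one step is a thin basis.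

For compound 4 in this assay the expected value is 15%, estimated to fall between -5% and 35%.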

Compound 4, a percentage reported as inhibition, in the whole organism at one dose (the size of the read-out at that dose, not a potency): -1.5%
Estimate against measurement, compound 4: 16.5 percentage points above; the range from low to high includes it.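

In this assay aminomethyl in place of cyano on the core of compound 3 gives a number 32.2 percentage points lower from compound 3 to compound 4 (beyond the scatter) and so lowers the number on this core as well. The direction of the step holds on both cores, but two pairs say nothing about any further core or about what sets the size of the step. The size itself does not carry over unchanged: the same change on two cores in this assay, a number 15.3 percentage points lower (beyond the scatter) from compound 1 to compound 2 and a number 32.2 percentage points lower (beyond the scatter) from compound 3 to compound 4, 16.9 percentage points apart, beyond the scatter of two such steps

The compounds shown leave open whether aminoethyl, with its longer chain, would give a step of either size on these two cores. Also open, going by these compounds, is whether an amide or an ester in place of the carboxylic acid would keep the same difference between the cores.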